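The source may report more compounds than this note shows. Statements on the series, on what has been measured and on what is new or still open speak of the compounds shown alone.

Measured compounds:
- compound 1 `COc1ccc(CNC(=O)c2ccc(C3c4nc[nH]c4CCN3Cc3cccc(Cl)c3)cc2)cc1`: in an ADME assay on HepG2 cells (Homo sapiens) for cytotoxicity (on this read-out higher numbers stand for lower toxicity in this test and lower numbers for higher toxicity in this test), compound 1 gives > 12.8 uM, which is a limit of the assay rather than a number.
- compound 2 `COc1ccc(CNC(=O)c2ccc(C3c4nc[nH]c4CCN3c3ccc4ccccc4c3)cc2)cc1`: in this assay compound 2 gives > 12.4 uM, again a limit of the assay.

Among the compounds with values here, compound 1 stands only at a limit in this assay; the one other value shown is a limit as well. Within the data shown here, the single measured step, a step that the two limits leave unreadable from compound 1 to compound 2, cannot be read in size because both ends are limits, as the limit of > 12.4 uM in this assay, at which 1 of the 2 values shown sits, and the limit of > 12.8 uM in this assay, at which 1 of the 2 values shown sits, show.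

The change followed here is 2,4,5-trimethoxyphenyl in place of 3-chlorophenyl on a saturated chain carbon bound to an amine nitrogen in a ring, giving compound 3 `COc1ccc(CNC(=O)c2ccc(C3c4nc[nH]c4CCN3Cc3cc(OC)c(OC)cc3OC)cc2)cc1`. Among the measured compounds shown here, no measured step touches this kind of change, and the step from compound 1 to compound 2, which swaps a different group, gives no readable size. For the measured compounds named here, the only guidance is that both measured compounds sit at the limit in this assay, so compound 3 is expected to do the same, with an estimated step that the limit leaves unreadable from compound 1 to compound 3. For compound 3 the estimate in this assay is 15 uM, with a range from 7 uM to 40 uM.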

Compound 3, half-maximal toxic concentration: > 11.5 uM
Compound 3 ended at the assay's limit; the forecaster's own chance of this, stated with the estimate: 70%; the middle value lies beyond the limit too.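

In this assay, compound 3 gives only a limit of the assay, as compound 1 does, so the step from compound 1 to compound 3 cannot be read. The compounds shown leave open the concentration at which compound 1, compound 2 or compound 3 would reach the half-maximal toxic level, and whether the three differ at all.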